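Nitro for bromo on the anilide ring of compound 1

This account rests on a few compounds, and the source may have more. Where it says the series, first, only, none or still open, it means among the compounds named here.

Measured compounds:
compound 1, `O=C(CSc1nncnc1-c1ccccc1Cl)Nc1ccccc1Br`, 73000 nM
compound 2, `CC(=O)c1ccc(NC(=O)CSc2nncnc2-c2cccc3ccccc23)c(Br)c1`, 133000 nM
compound 3, `O=C(CSc1nncnc1-c1ccccc1Cl)N1CCCc2ccccc21`, 35000 nM

Three compounds sharing the same core were tested in an ADME assay on MT4 cells (Homo sapiens) for cytotoxicity, read by MTT assay; a lower number here means that less compound is tolerated, a higher number that more compound is tolerated. Compound 1 gives 73000 nM, which places it second highest among the three. Its nearest neighbour is compound 2 with 133000 nM, a gap that lies within the scatter, so the two cannot be told apart. Compound 3 gives 35000 nM, lower than compound 1 by a margin beyond the scatter.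

Compound 4, `O=C(CSc1nncnc1-c1ccccc1Cl)Nc1ccccc1[N+](=O)[O-]`, has not yet been measured in this assay. It differs from compound 1 in one place: nitro in place of bromo on an aromatic carbon, ortho to a large group on the six-membered carbon ring. Among the measured compounds shown here, no step between measured compounds covers this change, so the expectation rests only on compound 1 itself. The step is expected to be small, with the number for compound 4 staying near that of compound 1 and no change beyond the scatter, a 1.2-fold lower number from compound 1 to compound 4 (0.09 log units; within the scatter). Compound 4 is therefore estimated at 60000 nM, within a range from 20000 nM to 180000 nM.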

Compound 4, half-maximal cytotoxic concentration: 63000 nM
Compound 4: middle estimate off by 1.1-fold (0.02 log units), on the low side; low and high end bracket the measured number.
By their numbers in this assay, from the lowest: compounds 3, 4, 1 and 2 (each within the scatter of the next, the first and the last beyond it).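

Read as a single change, 2-bromophenyl to 2-nitrophenyl gives a 1.2-fold lower number from compound 1 to compound 4 (0.06 log units; within the scatter) in this assay, the first step in this set that differs in one place only. At this position on the ring, ortho to a large group, three heavy atoms with two hydrogen-bond acceptors thus replace a single bromine with no change that can be told from the scatter. No evidence is at hand that bears on this result.

Going by these compounds, whether other groups at this place, such as an amine, a carboxylic acid or a methoxy group, would also stay within the scatter of compound 1 remains open. So does whether nitro in place of bromo would read the same on compound 2, which also carries a bromo group.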